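Urea to Benzamide: Expecting a Modest Loss of Inhibition

The source may hold more compounds than are shown below. What is called first, only, known or untested is meant among the compounds shown, and "the series" means these compounds.

Of the compounds shown here, three sharing one core have been tested in a functional assay on HOP-92 cells (Homo sapiens) for inhibition, read by sulforhodamine B assay, with a stated time of 48 h; on this read-out higher numbers stand for weaker inhibition and lower numbers for stronger inhibition. Compound 1 `O=C(Nc1cccc(-n2cc(-c3ccncc3)c(-c3ccc(Cl)c(O)c3)n2)c1)Nc1cccc(C(F)(F)F)c1` gives 510 nM. Compound 2 `COc1cc(-c2nn(-c3cccc(NC(=O)Nc4cc(C(F)(F)F)cc(C(F)(F)F)c4)c3)cc2-c2ccncc2)ccc1Cl` gives 140 nM. Compound 3 `COc1cc(-c2nn(-c3cccc(NC(=O)Nc4cccc(C(F)(F)F)c4)c3)cc2-c2ccncc2)ccc1Cl` gives 560 nM, the highest number of the three, though its gap to compound 1 is within the scatter: a 1.1-fold higher number from compound 1 to compound 3 (0.04 log units; within the scatter). Against compound 2 the gap is real but modest: a 4.0-fold higher number from compound 2 to compound 3 (0.60 log units; beyond the scatter).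

Compound 4 `COc1cc(-c2nn(-c3cccc(NC(=O)c4ccccc4)c3)cc2-c2ccncc2)ccc1Cl` has not yet been measured. It differs from compound 3 in one place: phenyl in place of (3-(trifluoromethyl)phenyl)amino on a carbonyl carbon. The group that leaves carries a trifluoromethyl and a hydrogen-bond donor; the phenyl that enters carries neither. Going by the values given here, the only measured step that touches this change is a 4.0-fold higher number from compound 2 to compound 3 (0.60 log units; beyond the scatter), in which dropping a single trifluoromethyl gave a modest rise in the number. Among the compounds with values here, no measured pair shows what removing the nitrogen does, so that part is a guess. Compound 4 is therefore expected to show weaker inhibition, with an estimated step of a 3.2-fold higher number from compound 3 to compound 4 (0.51 log units; beyond the scatter). Compound 4 is estimated at 1800 nM, likely falling between 600 nM and 6000 nM.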

Compound 4, half-maximal inhibitory concentration: 320 nM
Compound 4: middle estimate off by 5.6-fold (0.75 log units), on the high side; the measured number lies below the stated range.
By their numbers in this assay, from the lowest: compound 2; then compounds 4, 1 and 3 (each within the scatter of the next).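

In this assay, replacing (3-(trifluoromethyl)phenyl)amino with phenyl on the carbonyl carbon gives a 1.8-fold lower number from compound 3 to compound 4 (0.24 log units; within the scatter) and so does not produce the expected loss of inhibition. The urea nitrogen with its hydrogen-bond donor and the trifluoromethyl can therefore both leave this position together without a change beyond the scatter, even though the earlier pair showed that a second trifluoromethyl on the urea series counts, with a 4.0-fold higher number from compound 2 to compound 3 (0.60 log units; beyond the scatter) in this assay. Nothing available here explains why the number holds up after the swap.

From the compounds shown here alone, it remains open whether the benzamide series would respond to a trifluoromethyl on its phenyl as the urea series does. It is also unclear whether any ring is needed on this carbonyl carbon, and a methyl or a morpholine in place of phenyl would test that.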